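A few compounds are considered here, and "the series" means these few. Any claim that something is new, unique, unknown or untested is made for them only; others in the source may bear on it.

Compound 3, with the structure `CCCCCCCCCCCCCC[C@H](OCOC)[C@H](CN(C(C)C)C(C)C)NC(=O)OC(C)(C)C`, stands highest among the three compounds measured in a functional assay on MDA-MB-231 cells (Homo sapiens) for antiproliferative activity, read by sulforhodamine B assay, with a stated time of 48 h, tested at 10 uM (a lower number here means less inhibition, a higher number more inhibition at the concentration tested (going by the name of the read-out)), where compound 3 gives 31%. Compound 2, with the structure `CCCCCCCCCCCCCC[C@H](OCOC)[C@H](CN(CC)CC)NC(=O)OC(C)(C)C`, gives 0.84% in this assay, and compound 1, with the structure `CCCCCCCCCCCCCC[C@H](O)[C@H](CO[Si](c1ccccc1)(c1ccccc1)C(C)(C)C)NC(=O)OC(C)(C)C`, gives -37.5%. For the measured compounds named here, the only measured step that changes the amine at this place is a number 30.2 percentage points higher from compound 2 to compound 3 (beyond the scatter), a large rise in inhibition.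

Compound 4 has the structure `CCCCCCCCCCCCCC[C@H](OCOC)[C@H](CN1CCN(C)CC1)NC(=O)OC(C)(C)C`. It differs from compound 3 in one place: 4-methylpiperazin-1-yl in place of diisopropylamino on a saturated chain carbon, two bonds along the chain from an amide-type nitrogen. The earlier step went from diethylamino to diisopropylamino on the same saturated chain carbon, and it was large, so the amine at this position clearly matters. Going by the values given here, there is, however, no measured step from an open-chain amine to a ring such as 4-methylpiperazin-1-yl, so the direction is uncertain. Because the diethylamino compound sits far below in a number 30.2 percentage points higher from compound 2 to compound 3 (beyond the scatter), a move away from diisopropylamino is expected to cost some inhibition rather than add to it. Compound 4 is therefore estimated at 15%, with a range from -10% to 40%, meaning an expected step of a number 16 percentage points lower from compound 3 to compound 4 (beyond the scatter) downward, though a result within the scatter of compound 3 would not be surprising.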

Compound 4, a percentage reported as inhibition, at one concentration (the size of the read-out at that concentration, not a potency): 24%
Compound 4: the middle estimate sits 9 percentage points below what was measured; the range from low to high includes it.
By their numbers in this assay, from the lowest: compound 1; then compound 2; then compounds 4 and 3 (each within the scatter of the next).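

The new result shows that a ring can stand at this place, on a saturated chain carbon, two bonds along the chain from an amide-type nitrogen: in this assay, replacing diisopropylamino with 4-methylpiperazin-1-yl gives a number 7 percentage points lower from compound 3 to compound 4 (within the scatter), so these two amines cannot be told apart in this assay. The comparison with diethylamino reads a number 23.2 percentage points higher from compound 2 to compound 4 (beyond the scatter), which means that compound 2 now stands apart from two different amines, one open-chain and one ring, rather than from a single partner. No measurement available here accounts for why diethylamino differs from the other two amines.

From the compounds shown here alone, it remains open whether a ring without the second nitrogen, such as piperidin-1-yl, or one with an oxygen in its place, such as morpholin-4-yl, would group with compound 3 and compound 4 or with compound 2, and the same is true of a smaller group such as a primary amine or dimethylamino. Also unresolved is the contribution of the long tetradecyl chain and the methoxymethyl ether, since compound 1 differs from the others in more than one place and so gives no clean comparison.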